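The source may hold more compounds than are shown below. What is called first, only, known or untested is meant among the compounds shown, and "the series" means these compounds.

Compound 2 `CCC(C)(C)Cc1c[nH]c(CCc2ccc(-c3cccc(C#N)n3)cc2)n1` gives 193 nM in a functional assay on HEK293 cells for agonist activity at Bombesin receptor subtype-3 (Homo sapiens), read by luminescence and calcium flux, with a stated time of 10 min (on this read-out higher numbers stand for an effect only at larger amounts of compound and lower numbers for an effect already at smaller amounts), and stands second highest among the three measured numbers. Its nearest neighbour is compound 1 `CCC(C)(C)Cc1c[nH]c(CCc2ccc(-n3cccn3)cc2)n1`, which gives 135 nM in this assay, the step of a 1.4-fold higher number from compound 1 to compound 2 (0.16 log units; within the scatter). Furthest away is compound 3 `c1ccc(-c2ccc(CCc3nc(CC4CCCC4)c[nH]3)cc2)nc1`, which gives 425 nM in this assay, a higher number beyond the scatter.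

Compound 4 `CCC(C)(C)Cc1c[nH]c(CCc2ccc(-c3ccns3)cc2)n1` differs from compound 2 in one place: 1,2-thiazol-5-yl in place of 6-cyanopyridin-2-yl on an aromatic carbon. Among the compounds with values here, the only step that bears on this is the one from compound 1 to compound 2, where a five-membered ring with two hetero atoms was exchanged for the 6-cyanopyridin-2-yl group, and that step stayed within the scatter. Reversing towards a five-membered ring with two hetero atoms is therefore expected to give no step beyond the scatter, a 1.2-fold lower number from compound 2 to compound 4 (0.08 log units; within the scatter). Compound 4 is estimated at 160 nM, between 60 nM and 420 nM.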

Compound 4, half-maximal effective concentration: 63 nM
Beside the measured number, compound 4's estimate is 2.5-fold (0.40 log units) above it, within the range that was stated.
By their numbers in this assay, from the lowest: compound 4; then compounds 1 and 2 (each within the scatter of the next); then compound 3.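

In this assay the step of a 3.1-fold lower number from compound 2 to compound 4 (0.49 log units; beyond the scatter) shows that the group on this aromatic carbon, para to a large group, can move the number beyond the scatter, which the earlier exchange did not show. The step of a 2.1-fold lower number from compound 1 to compound 4 (0.33 log units; beyond the scatter) adds that two five-membered aromatic rings with 2 hetero atoms need not behave alike here. Nothing available explains either step.

The compounds shown leave open whether a thiophene or 1,3-thiazol-5-yl ring in this place would give a similar number. They also leave open how an amine on this ring would compare.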